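Naphthalen-2-yl in place of 4-chlorophenyl on the sulfonyl

This account rests on a few compounds, and the source may have more. Where it says the series, first, only, none or still open, it means among the compounds named here.

Compound 1 `O=S(=O)(NC1=NCCN1C(=S)SN1CCn2c1nsc2=S)c1cccc(Cl)c1`: >= 20000 nM in a functional assay on KYSE-510 cells (Homo sapiens) for antiproliferative activity, read by crystal violet staining, with a stated time of 96 h; on this read-out higher numbers stand for weaker inhibition of growth and lower numbers for stronger inhibition of growth
Compound 2 `O=S(=O)(NC1=NCCN1C(=S)SN1CCn2c1nsc2=S)c1ccc(Cl)cc1`: >= 20000 nM

In this assay compound 2 stands at a limit of the measurement, >= 20000 nM, not at a measured number. The same limit holds for compound 1, so the step that the two limits leave unreadable from compound 1 to compound 2 cannot be read. Both values sit where the limit of >= 20000 nM in this assay, at which 2 of the 2 values shown sit, sits. Compound 3 `O=S(=O)(NC1=NCCN1C(=S)SN1CCn2c1nsc2=S)c1ccc2ccccc2c1` differs from compound 2 by naphthalen-2-yl in place of 4-chlorophenyl on a sulfonyl sulfur. Among the measured compounds shown here, no measured step bears on this change, so no direction or size beyond the scatter can be derived. Compound 3 is therefore expected to remain near the limit, with an estimated 20000 nM between 8000 nM and 50000 nM; the expected step is a number no higher from compound 2 to compound 3 (the limit leaves the size open).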

Compound 3, concentration for 50% growth inhibition: >= 20000 nM
Compound 3: a limit, no number (the forecaster's own chance of this, stated with the estimate: 70%); the middle value sits exactly at the limit.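

Compound 1, compound 2 and compound 3 all stand at a limit and not at a number, so no step among them can be read: the limit of >= 20000 nM in this assay, at which 3 of the 3 values shown sit.

The compounds shown leave open whether changing the group on the sulfonyl sulfur alters growth inhibition at all, and in which direction.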